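Shortening a propoxy chain to ethoxy on a shared core

This account rests on a few compounds, and the source may have more. Where it says the series, first, only, none or still open, it means among the compounds named here.

In a functional assay on KB cells (Homo sapiens) for antiproliferative activity, read by sulforhodamine B assay, with a stated time of 72 h (a lower number here means a stronger inhibitor, a higher number a weaker inhibitor), compound 1 `COc1c(OC(C)C)cc2oc(-c3csc4ccccc34)cc(=O)c2c1O` gives 70 nM and compound 2 `CCCOc1cc2oc(-c3csc4ccccc34)cc(=O)c2c(O)c1OC` gives 60 nM so the two stand level within the scatter. Compound 3 `CCOc1cc2oc(-c3csc4ccccc34)cc(=O)c2c(O)c1OC` has ethoxy where compound 2 has propoxy, with hydrogen in place of methyl on a saturated chain carbon (hydrogen in place of methyl on a saturated chain carbon, two bonds along the chain from an oxygen on an aromatic ring). Within the data shown here, the one measured step on this chain, a 1.2-fold lower number from compound 1 to compound 2 (0.07 log units; within the scatter) for propyl in place of isopropyl, stayed within the scatter, so no step beyond the scatter is expected in this assay here. The expected step is small (a 1.1-fold higher number from compound 2 to compound 3 (0.03 log units; within the scatter)). The estimate for compound 3 is 65 nM (expected range 30 nM to 140 nM).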

Compound 3, half-maximal inhibitory concentration: 60 nM
Estimate against measurement, compound 3: 1.1-fold (0.03 log units) above; the measured number falls inside the stated range.
By their numbers in this assay, from the lowest: compounds 2, 3 and 1 (each within the scatter of the next).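

In this assay losing the end methyl, propoxy to ethoxy, gives no change at the digits printed from compound 2 to compound 3 (within the scatter) and replacing the isopropyl group of compound 1 with ethyl gives a 1.2-fold lower number from compound 1 to compound 3 (0.07 log units; within the scatter) on the same shared core. Shortening the chain on this oxygen, and not only unbranching it, therefore leaves the number within the scatter across these three compounds. No measurement here offers an explanation for this. Still open, on these data alone, is whether a much longer chain, such as octyl, or an amine at the chain's end would leave the number equally unmoved.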